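Removing the chloro of compound 2 in the A549 growth assay

The compounds below may be only part of what the source reports. "The series", "measured", "known", "first", "only" and "open" are said of these compounds alone.

The series shares one core, a substituted urea on a pyrimidine bearing an indolylthio group and an amine. Compound 1 `Cc1cc(Cl)ccc1NC(=O)Nc1nc(NC2CC2)cc(Sc2c[nH]c3ccccc23)n1` carries a cyclopropylamino group and a methyl on the aryl urea; in a functional assay on A549 cells (Homo sapiens) for inhibition, with a stated time of 72 h (a higher number here means a weaker inhibitor, a lower number a stronger inhibitor), compound 1 gives 31500 nM. Compound 2 `O=C(Nc1ccc(Cl)cc1)Nc1nc(Sc2c[nH]c3ccccc23)cc(N2CCCC2)n1` has a pyrrolidine in place of the cyclopropylamino and no methyl; in this assay compound 2 gives 6410 nM. Within the data shown here, of the two numbers measured so far, compound 2 stands lowest, and the gap to compound 1 lies beyond the usual scatter.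

Among the measured compounds shown here, compound 3 `O=C(Nc1ccccc1)Nc1nc(Sc2c[nH]c3ccccc23)cc(N2CCCC2)n1` is the next step: the only change from compound 2 is hydrogen in place of chloro on an aromatic carbon, on an aromatic carbon of a six-membered aromatic ring of carbon only, para to a large group. For the measured compounds named here, no pair of measured compounds differs at this position, so the size of this step cannot be read off the data. A single-atom loss of this kind is expected to shift this assay only modestly, most likely towards a weaker inhibitor, and a step of a 1.6-fold higher number from compound 2 to compound 3 (0.19 log units; within the scatter) is estimated. For compound 3 the expected value in this assay is therefore 10000 nM, with a range from 4000 nM to 25000 nM.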

Compound 3, half-maximal inhibitory concentration: 21200 nM
Estimate against measurement, compound 3: 2.1-fold (0.33 log units) below; measured number inside the range.
By their numbers in this assay, from the lowest: compound 2; then compounds 3 and 1 (each within the scatter of the next).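

Among these compounds, replacing the 4-chlorophenyl on the urea with phenyl gives a 3.3-fold higher number from compound 2 to compound 3 (0.52 log units; beyond the scatter) in this assay, the first step that changes only one place, and the loss of the chloro weakens inhibition. The change is small in what is counted, with one chlorine leaving, no ring involved and no hydrogen-bond donor or acceptor changing, yet the step lies beyond the scatter, so the substituent at this position on the aromatic ring is not neutral for this read-out in the pyrrolidine-bearing compounds. Nothing at hand bears on the reason for this step.

From the compounds shown here alone, whether the effect is specific to chlorine remains open, since a fluoro, bromo, methyl, methoxy or nitrile group on the same aromatic carbon would show whether other groups match the chloro of compound 2 or fall back towards the hydrogen of compound 3. Also open, going by these compounds, is whether the step carries over to compounds with a cyclopropylamino group in place of the pyrrolidine, as this single pair rests on the pyrrolidine alone.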